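Lengthening the carbamate chain on a shared core

The compounds below may be only part of what the source reports. "The series", "measured", "known", "first", "only" and "open" are said of these compounds alone.

Compound 1, `COC(=O)N1N=C(c2ccccc2)NN=C1c1ccccc1`, in a functional assay on A549 cells (Homo sapiens) for antiproliferative activity, read by sulforhodamine B assay; a lower number here means a stronger inhibitor, a higher number a weaker inhibitor: 39500 nM; 39500 nM (2 entries).
Compound 2, `CCOC(=O)N1N=C(c2ccccc2)NN=C1c1ccccc1`, in this assay: > 100000 nM.

Among the measured compounds shown here, compound 1 carries a methyl carbamate on the shared core and gives the only single number here, with both of its entries in this assay agreeing at 39500 nM; 39500 nM (2 entries). Compound 2 carries the ethyl carbamate instead, and in this assay compound 2 gives > 100000 nM, which is a limit of the assay and not a number. Compound 2 therefore stands at the limit of > 100000 nM in this assay, at which 1 of the 2 values shown sits, with no single value to place it against compound 1.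

Compound 3, `CCCOC(=O)N1N=C(c2ccccc2)NN=C1c1ccccc1`, not yet measured, differs from compound 2 by methyl in place of hydrogen on a saturated chain carbon, two bonds along the chain from an oxygen next to a carbonyl group: ethoxy to propoxy, the methyl in place of hydrogen on a saturated chain carbon, two bonds along the chain from an oxygen next to a carbonyl group. With compound 2 already at a limit, no step beyond the scatter is expected in this assay, and compound 3 is most likely to be reported as a limit as well. The expected step is a step that the limit leaves unreadable from compound 2 to compound 3. Compound 3 is estimated at 150000 nM, between 50000 nM and 400000 nM.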

Compound 3, half-maximal inhibitory concentration: > 100000 nM
Compound 3 gave a limit, no number; the forecaster's own chance of this, stated with the estimate: 75%; the middle value does not contradict the limit.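

In this assay compound 3 gives > 100000 nM, which is a limit of the assay and not a number. Compound 2 also stands at a limit, and no step can be read between compound 2 and compound 3. The compounds shown leave open what single number either compound would have in this assay, and how large the step from ethoxy to propoxy is.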